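A few compounds are considered here, and "the series" means these few. Any claim that something is new, unique, unknown or untested is made for them only; others in the source may bear on it.

This study follows a small family of compounds built on one shared core, each examined in a physicochemical assay for lipophilicity, at pH 7.4; a higher number here means a more lipophilic compound, a lower number a more polar compound. Compound 1, `Cc1cc(C)c(CN2CCc3c(Cl)cc([C@@H](CO)[C@@H]4CCCO4)c(Cl)c3C2=O)c(=O)[nH]1`, gives 2.1 in this assay, the lowest of the three numbers recorded so far. Compound 2, `COC(c1cc(Cl)c2c(c1Cl)C(=O)N(Cc1c(C)cc(C)[nH]c1=O)CC2)C1CCOCC1`, gives 3.4; 3.5 (2 entries) in this assay, and compound 3, `COC(c1cc(Cl)c2c(c1Cl)C(=O)N(Cc1c(C)cc(C)[nH]c1=O)CC2)C1CCN(C(C)=O)CC1`, gives 2.9; 2.9 (2 entries) in this assay. The repeated entries for compound 2, (the several entries of compound 2 in this assay, 3.4; 3.5 (2 entries)), show how closely repeat measurements of this kind agree with one another.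

The step of interest leads from compound 1 to compound 4, `Cc1cc(C)c(CN2CCc3c(Cl)cc([C@@H](CO)[C@H]4CCCO4)c(Cl)c3C2=O)c(=O)[nH]1`, which has not yet been measured in this assay. The change between them is the two compounds have the same atoms and bonds and differ only in configuration as drawn: 1 of 2 stereo elements differ; a stereocentre at a saturated ring carbon is drawn S in compound 1 and R in compound 4. With every atom and bond kept and only the drawn configuration at one stereocentre altered, the step is expected to be no change at the digits printed from compound 1 to compound 4 (within the scatter), that is, no shift beyond the usual scatter of this assay. Compound 4 is therefore expected to give about 2.1 in this assay, within a range from 1.8 to 2.4.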

Compound 4, distribution coefficient: 2.5
Estimate against measurement, compound 4: 0.40 log units below; the measured number lies above the stated range.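

In this assay, the drawn configuration at this saturated ring carbon makes a readable difference: the record shows a number 0.40 log units higher from compound 1 to compound 4 (beyond the scatter). The earlier compounds offered no such reading, since no two of them differ in one place only, and this step is larger than the spread between repeat measurements: the several entries of compound 2 in this assay, 3.4; 3.5 (2 entries) The shift can be assigned to the configuration at this stereocentre because nothing else separates the pair: the fact that compounds 1 and 4 differ only in the configuration as drawn

The compounds shown leave open what changing the second stereocentre would do, and why inverting this one moves the number at all. They also leave open whether the same inversion would give a similar step in a compound carrying an amine or a carboxylic acid on the shared core.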